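The compounds below may be only part of what the source reports. "The series", "measured", "known", "first", "only" and "open" are said of these compounds alone.

Measured so far:
compound 1 `CCN(CC)c1ccc(NC(=O)c2cc(Cl)ccc2O)c(Cl)c1`: 55500 nM
compound 2 `O=C(Nc1ccc(N(CC2CC2)CC2CC2)cc1Cl)c1cc(Cl)ccc1O`: 12800 nM

In an ADME assay on A549 cells (Homo sapiens) for cytotoxicity, read by resazurin assay, with a stated time of 48 h (on this read-out higher numbers stand for lower toxicity in this test and lower numbers for higher toxicity in this test), compound 2 gives 12800 nM, the lower of the two numbers, while compound 1 gives 55500 nM. For the measured compounds named here, the only measured step is a 4.3-fold lower number from compound 1 to compound 2 (0.64 log units; beyond the scatter), and it comes from putting bis(cyclopropylmethyl)amino in place of diethylamino on an aromatic carbon.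

Compound 3 `O=C(Nc1ccc(NCc2ccccc2)cc1Cl)c1cc(Cl)ccc1O` changes the same place again, with benzylamino in place of bis(cyclopropylmethyl)amino on an aromatic carbon. Going by the values given here, no measured compound carries benzylamino, so the data offer no direct guide to this group. Among the compounds with values here, the one relevant comparison is a 4.3-fold lower number from compound 1 to compound 2 (0.64 log units; beyond the scatter), a modest step at this same place, and it sets the rough scale of what may be expected in this assay. Within the data shown here, with compound 2 at the low end of only two numbers, a slight rise is thought somewhat more likely than a further fall, though this is weak evidence. The expected step is a 1.4-fold higher number from compound 2 to compound 3 (0.15 log units; within the scatter), which would stay inside the usual scatter. For compound 3 the estimate is 18000 nM, with an expected range of 6000 nM to 50000 nM.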

Compound 3, half-maximal cytotoxic concentration: 19700 nM
Compound 3: the middle estimate sits 1.1-fold (0.04 log units) below what was measured, within the range that was stated.
By their numbers in this assay, from the lowest: compounds 2 and 3 (each within the scatter of the next); then compound 1.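

In this assay, benzylamino brings one hydrogen-bond donor and a six-membered aromatic ring where bis(cyclopropylmethyl)amino has no donor and two three-membered rings, yet the change gives only a 1.5-fold higher number from compound 2 to compound 3 (0.19 log units; within the scatter); at this position on the aromatic carbon, two quite different groups thus give numbers that this test does not separate. The comparison with diethylamino gives a 2.8-fold lower number from compound 1 to compound 3 (0.45 log units; beyond the scatter), so among these three compounds, each of the two replacements of diethylamino gives a lower number beyond the scatter, and compound 1 stands apart from the other two. No supporting measurement accounts for these numbers or tells what the three groups contribute to them.

Compound 3 alters the hydrogen-bond donor count and the ring type in a single change, leaving the contribution of each unresolved. A benzyl(methyl)amino group would keep the aromatic ring without the donor, while a simple unsubstituted amine would keep a donor without the ring, and the compounds shown do not reveal how either would read in this assay.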